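Dropping One Trifluoromethyl: What the Numbers Suggest

The compounds below may be only part of what the source reports. "The series", "measured", "known", "first", "only" and "open" are said of these compounds alone.

Three compounds have been tested in a functional assay on OVCAR-5 cells (Homo sapiens) for inhibition, read by sulforhodamine B assay, with a stated time of 48 h, tested at 0.01 uM; a lower number here means a stronger effect, a higher number a weaker effect of the compound at the concentration tested:
compound 1 `O=C(Nc1cccc(-n2cc(-c3ccncc3)c(-c3cc(O)cc(Cl)c3)n2)c1)Nc1ccc(Cl)c(C(F)(F)F)c1` gives 98%;
compound 2 `O=C(Nc1cccc(-n2cc(-c3ccncc3)c(-c3cc(O)cc(Cl)c3)n2)c1)Nc1ccc(Cl)c(Cl)c1` gives 53%;
compound 3 `COc1cc(Cl)cc(-c2nn(-c3cccc(NC(=O)Nc4cc(C(F)(F)F)cc(C(F)(F)F)c4)c3)cc2-c2ccncc2)c1` gives 99%.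

Compound 3 shows the highest of the three numbers, sitting within the scatter of compound 1 and well apart from compound 2. Compound 4 `COc1cc(Cl)cc(-c2nn(-c3cccc(NC(=O)Nc4cccc(C(F)(F)F)c4)c3)cc2-c2ccncc2)c1` differs from compound 3 by hydrogen in place of trifluoromethyl on an aromatic carbon. Among the measured compounds shown here, the one measured step that bears on this is a number 45 percentage points lower from compound 1 to compound 2 (beyond the scatter), where a trifluoromethyl gave way to chloro and the number fell sharply. Removing a trifluoromethyl outright may act in the same direction, though it is not the same change, so the expectation is tentative. For compound 4 the number is expected to shift by a number 19 percentage points lower from compound 3 to compound 4 (beyond the scatter) in this assay, with an estimate of 80%, ranging from 50% to 100%.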

Compound 4, a percentage reported as activity, at one concentration (the size of the read-out at that concentration, not a potency): 94%
Beside the measured number, compound 4's estimate is 14 percentage points below it; the range from low to high includes it.
By their numbers in this assay, from the lowest: compound 2; then compounds 4, 1 and 3 (each within the scatter of the next).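

In this assay, the step is a number 5 percentage points lower from compound 3 to compound 4 (within the scatter), so on this ring one trifluoromethyl can give way to hydrogen without a clear change while the other stays in place. The large fall of a number 45 percentage points lower from compound 1 to compound 2 (beyond the scatter) therefore does not hold for every loss of a trifluoromethyl from this ring. Nothing available explains this difference.

Still open, as far as these compounds go, is what happens when the remaining trifluoromethyl is also replaced by hydrogen. Also open, from the compounds shown here alone, is whether an amine or a carboxylic acid at this place would leave the number as little changed.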